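Aryl Ether Variation and Expected Potency of Compound 4

The source may hold more compounds than are shown below. What is called first, only, known or untested is meant among the compounds shown, and "the series" means these compounds.

Compound 2 `Cc1nn(C)c(Oc2cccc(F)c2)c1/C=N\CCCCCCOc1cc2oc(=O)cc(C)c2cc1Cl` belongs to a small set sharing one core and differing only in the aryl group on the ether oxygen. In a functional assay on SMMC-7721 cells (Homo sapiens) for antiproliferative activity, read by MTT assay, with a stated time of 72 h (a higher number here means a weaker inhibitor, a lower number a stronger inhibitor), compound 2 gives 23600 nM. Compound 1 `Cc1nn(C)c(Oc2ccccc2F)c1/C=N\CCCCCCOc1cc2oc(=O)cc(C)c2cc1Cl` is reported in this assay only as a limit, > 25000 nM, as the limit of > 25000 nM in this assay, at which 1 of the 3 values shown sits, records. Compound 3 `Cc1nn(C)c(Oc2ccc(I)cc2)c1/C=N\CCCCCCOc1cc2oc(=O)cc(C)c2cc1Cl` gives 13300 nM in this assay. Compound 2 thus holds the higher of the two actual numbers, the steps of an at least 1.0-fold lower number from compound 1 to compound 2 (0.02 log units; that floor lies within the scatter) and a 1.8-fold lower number from compound 2 to compound 3 (0.25 log units; within the scatter) both staying small. Compound 4 `Cc1nn(C)c(Oc2ccc(OC(F)(F)F)cc2)c1/C=N\CCCCCCOc1cc2oc(=O)cc(C)c2cc1Cl` differs from compound 2 by 4-(trifluoromethoxy)phenyl in place of 3-fluorophenyl on an oxygen on an aromatic ring. Among the compounds with values here, the nearest precedent, a 1.8-fold lower number from compound 2 to compound 3 (0.25 log units; within the scatter), points to a modest downward move at most. Compound 4 is therefore expected near 15000 nM, between 6000 nM and 30000 nM. The expected step is a 1.6-fold lower number from compound 2 to compound 4 (0.20 log units; within the scatter).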

Compound 4, half-maximal inhibitory concentration: 6350 nM
For compound 4 the middle estimate is 2.4-fold (0.37 log units) above the measured one; low and high end bracket the measured number.
By their numbers in this assay, from the lowest: compound 4; then compounds 3 and 2 (each within the scatter of the next). At a limit, above all of these: compound 1.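

Within the data shown here, with 4-(trifluoromethoxy)phenyl on the ether oxygen, this position gives steps beyond the scatter in this assay (a 3.7-fold lower number from compound 2 to compound 4 (0.57 log units; beyond the scatter); a 2.1-fold lower number from compound 3 to compound 4 (0.32 log units; beyond the scatter)), which no step among the earlier compounds with actual numbers did. The step from compound 1 also clears the scatter (an at least 3.9-fold lower number from compound 1 to compound 4 (0.59 log units; beyond the scatter)), but it is only a floor, and compound 1 is recorded as a limit: the limit of > 25000 nM in this assay, at which 1 of the 4 values shown sits. The compounds shown leave open whether the same gain would follow from an amine, a carboxylic acid or a longer alkoxy chain on this phenyl ring. They also leave open how far the trifluoromethoxy group alone accounts for the step from compound 3.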